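The compounds below may be only part of what the source reports. "The series", "measured", "known", "first", "only" and "open" are said of these compounds alone.

Among the measured compounds shown here, in a functional assay on HeLa cells (Homo sapiens) for inhibition, read by CCK-8 assay, with a stated time of 48 h (a lower number here means a stronger inhibitor, a higher number a weaker inhibitor), three compounds built on a shared core have numbers so far. Compound 1 (`O=S(=O)(NCCNC(=S)Nc1cccc(Cl)c1)c1ccc(-c2ccccc2OCc2cccc(O)c2)s1`) gives 10700 nM, compound 2 (`O=C(NCCNS(=O)(=O)c1ccc(-c2ccccc2OCc2cccc(O)c2)s1)Nc1cc(C(F)(F)F)cc(C(F)(F)F)c1`) gives 17300 nM, and compound 3 (`O=S(=O)(NCCNC(=S)Nc1cccc(Cl)c1)c1ccc(-c2ccccc2OCc2ccccc2)s1`) gives 8400 nM. Compound 3 cannot be separated from compound 1, while its number is lower than that of compound 2 by a gap beyond the scatter.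

Compound 4 (`O=[N+]([O-])c1cccc(NC(=S)NCCNS(=O)(=O)c2ccc(-c3ccccc3OCc3ccccc3)s2)c1`) is compound 3 with a single change: nitro in place of chloro on an aromatic carbon, turning 3-chlorophenyl into 3-nitrophenyl (nitro in place of chloro on an aromatic carbon). The measurements offer only indirect guidance on this change. For the measured compounds named here, the one step between measured compounds that differ in one place is a 1.3-fold lower number from compound 1 to compound 3 (0.11 log units; within the scatter), which puts hydrogen in place of hydroxy on an aromatic carbon and stays within the scatter. Going by the values given here, that step does not touch the chloro group, so no measured step gives a size for the exchange at hand. Among the compounds with values here, with only that small step from compound 1 to compound 3 to go on, and with no direction indicated, no shift beyond the scatter is expected in this assay. The expected change is a 1.1-fold higher number from compound 3 to compound 4 (0.03 log units; within the scatter). For compound 4 the estimated value is 9000 nM, with an expected range of 4000 nM to 20000 nM.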

Compound 4, half-maximal inhibitory concentration: 12800 nM
Beside the measured number, compound 4's estimate is 1.4-fold (0.15 log units) below it; the measured number falls inside the stated range.
By their numbers in this assay, from the lowest: compounds 3, 1, 4 and 2 (each within the scatter of the next, the first and the last beyond it).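

In this assay, among the compounds shown here, the exchange of chloro for nitro gives a 1.5-fold higher number from compound 3 to compound 4 (0.18 log units; within the scatter), the first measured step at this aromatic carbon, as the only earlier step concerned a hydroxy group elsewhere in the molecule. The position thus takes nitro, with 3 heavy atoms and 2 hydrogen-bond acceptors, in place of chloro, with 1 heavy atom and no hydrogen-bond acceptors, and the two compounds cannot be told apart in this read-out. No measurement of any property of these two groups is available to bear on this result.

The compounds shown leave open whether this position would stay as flat with other groups on the same aromatic carbon, such as an amine, a methoxy group or a carboxylic acid, or with hydrogen in place of chloro. On these data alone, it also remains open whether the same exchange would give a step of similar size on compound 1, which carries the hydroxy group that compound 3 lacks.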